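Methoxy in place of fluoro on the fused core: compound 4

The source may hold more compounds than are shown below. What is called first, only, known or untested is meant among the compounds shown, and "the series" means these compounds.

The three measured compounds share one core and differ at two places, the amine-linked chain and the substituent on the carbocyclic ring. In a functional assay on MDA-MB-468 cells (Homo sapiens) for cytotoxicity, read by sulforhodamine B assay, with a stated time of 48 h, in the presence of a further agent that is not named here (on this read-out lower numbers stand for stronger inhibition of growth and higher numbers for weaker inhibition of growth), compound 1 `CCCCNc1ccnc2cc(F)ccc12` gives 3500 nM. In this assay compound 2 `CN(C)CCNc1ccnc2cc(Cl)ccc12` gives 19300 nM. In this assay compound 3 `CN(C)CCNc1ccnc2cc(F)ccc12` gives 7620 nM, the second highest of the three numbers. The step with dimethylamino in place of ethyl on the chain is a 2.2-fold higher number from compound 1 to compound 3 (0.34 log units; beyond the scatter); the step with fluoro in place of chloro on the aromatic carbon is a 2.5-fold lower number from compound 2 to compound 3 (0.40 log units; beyond the scatter).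

Compound 4 `COc1ccc2c(NCCN(C)C)ccnc2c1` differs from compound 3 by methoxy in place of fluoro on an aromatic carbon. Only the halogen swap bears on this site, and it was modest, a 2.5-fold lower number from compound 2 to compound 3 (0.40 log units; beyond the scatter). The chain step a 2.2-fold higher number from compound 1 to compound 3 (0.34 log units; beyond the scatter) concerns another part of the molecule. For the measured compounds named here, no measured compound carries methoxy at this position, so the size of the step rests on a single comparison. A step of similar or smaller size is expected in this assay, with the direction uncertain and the number more likely to move upward than downward. Compound 4 is expected to give 10000 nM, with a range from 3500 nM to 30000 nM. The estimated step is a 1.3-fold higher number from compound 3 to compound 4 (0.12 log units; within the scatter).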

Compound 4, concentration for 50% growth inhibition: 7620 nM
Beside the measured number, compound 4's estimate is 1.3-fold (0.12 log units) above it, and the stated range covers the measured number.
By their numbers in this assay, from the lowest: compound 1; then compounds 3 and 4 (each within the scatter of the next); then compound 2.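

In this assay the swap of fluoro for methoxy on this aromatic carbon, with the dimethylamino chain held constant, gives no change at the digits printed from compound 3 to compound 4 (within the scatter) and so leaves the read-out unmoved, although the entering group adds a heavy atom and a hydrogen-bond acceptor. Chloro now stands apart from both other groups at this site, since the methoxy swap gives a 2.5-fold lower number from compound 2 to compound 4 (0.40 log units; beyond the scatter) and matches in size the fluoro swap, which gives a 2.5-fold lower number from compound 2 to compound 3 (0.40 log units; beyond the scatter) on the same chain. The series therefore shows that this position tolerates a change from a single atom to methoxy with no loss in growth inhibition, and that chloro alone among the three groups carries the higher number, though nothing presented here offers an explanation for this.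

Going by these compounds, it remains open whether methoxy and fluoro would also stay level on the chain of compound 1, as the comparison rests on the dimethylamino chain alone. On these data alone, it also remains open how an ethoxy, a hydroxyl, a nitrile or a trifluoromethyl on this aromatic carbon would read, and whether any of them would lower the number below that of compound 3.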